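The compounds below may be only part of what the source reports. "The series", "measured", "known", "first", "only" and "open" are said of these compounds alone.

Working notes on the series. In an ADME assay on microsomes from liver (Homo sapiens) for metabolic stability, using NADPH, with a stated time of 10 min (on this read-out higher numbers stand for a more stable compound and lower numbers for a less stable compound), compound 1 `NC/C=C/CN(C[C@H]1Cc2ncccc2CN1)[C@H]1CCCc2cccnc21` gives 85%. Among the compounds with values here, compound 2 `c1cnc2c(c1)CN[C@@H](CN(CCCCNC1CCOCC1)[C@H]1CCCc3cccnc31)C2` gives 97%, the higher of the two numbers so far, and the only measured step is a number 12 percentage points higher from compound 1 to compound 2 (beyond the scatter), modest but beyond the scatter. Compound 3 `CN(CCCCN(C[C@H]1Cc2ncccc2CN1)[C@H]1CCCc2cccnc21)C1CCOCC1` carries methyl in place of hydrogen on an amine nitrogen, turning (oxan-4-yl)amino into methyl(oxan-4-yl)amino: methyl in place of hydrogen on an amine nitrogen. Within the data shown here, no measured step places a methyl on an amine nitrogen. Among the measured compounds shown here, the one step available bears only indirectly, since it alters the same end of the chain, and it gives no direct guide to size or direction. With so little evidence, no change beyond the scatter is expected, with a slight lean downward. The expected step is a number 6 percentage points lower from compound 2 to compound 3 (within the scatter). For compound 3 the estimated value is 91%, with an expected range of 78% to 99%.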

Compound 3, percent of the compound remaining: 100%
Beside the measured number, compound 3's estimate is 9 percentage points below it; the measured number lies above the stated range.
By their numbers in this assay, from the lowest: compound 1; then compounds 2 and 3 (each within the scatter of the next).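

In this assay, within the data shown here, methyl in place of hydrogen on an amine nitrogen whose other neighbours are a saturated chain carbon and a saturated ring carbon gives a number 3 percentage points higher from compound 2 to compound 3 (within the scatter), the first direct reading of a change at this nitrogen, and it shows no separation between the secondary amine and its methylated form. The larger replacement on the saturated chain carbon bound to an amine nitrogen, with the methyl included, gives a number 15 percentage points higher from compound 1 to compound 3 (beyond the scatter), so the separation from compound 1 holds with either form of this amine. Nothing available explains these readings.

From the compounds shown here alone, whether an ethyl or acetyl group on this amine nitrogen would read the same remains open. So does the effect of a cyclohexyl group in place of oxan-4-yl.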